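A few compounds are considered here, and "the series" means these few. Any claim that something is new, unique, unknown or untested is made for them only; others in the source may bear on it.

Measured in a functional assay on Chorioallantoic membrane (Gallus gallus, strain Leghorn), read by microscopy, with a stated time of 40 h; on this read-out lower numbers stand for stronger inhibition and higher numbers for weaker inhibition:
- compound 1 `COc1ccc(N(C)c2ncnc3occ(C)c23)cc1` gives 80 nM here
- compound 2 `COc1ccc(Nc2ncnc3occ(C)c23)cc1` gives 445 nM here
- compound 3 `CCc1ccc(N(C)c2ncnc3occ(C)c23)cc1` gives 287 nM here

Compound 3 stands toward the high end of these numbers. Its value is within the scatter of compound 2 and clearly apart from compound 1.

The next compound is compound 4 `CSc1ccc(N(C)c2ncnc3occ(C)c23)cc1`, with methylsulfanyl in place of ethyl on an aromatic carbon, para to a large group (methylsulfanyl in place of ethyl on an aromatic carbon).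

The measured step at this same place is a 3.6-fold higher number from compound 1 to compound 3 (0.55 log units; beyond the scatter), which is modest and beyond the scatter. The other step, a 5.6-fold higher number from compound 1 to compound 2 (0.75 log units; beyond the scatter), concerns the methyl on nitrogen, which compound 4 keeps, so it shows only the usual size of change in this small set. Within the data shown here, no measured compound carries methylsulfanyl, so the direction rests on thin evidence.

A small move toward stronger inhibition in this assay is expected, smaller than a 3.6-fold higher number from compound 1 to compound 3 (0.55 log units; beyond the scatter) in size. The expected step is a 1.9-fold lower number from compound 3 to compound 4 (0.28 log units; within the scatter) in this read-out. For compound 4 the estimate is 150 nM, with an expected range from 55 nM to 420 nM as the likely span.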

Compound 4, half-maximal inhibitory concentration: 520 nM
The estimate for compound 4 lay 3.5-fold (0.54 log units) below the measured number, and the stated range ends below it.
By their numbers in this assay, from the lowest: compound 1; then compounds 3, 2 and 4 (each within the scatter of the next).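

In this assay, methylsulfanyl in place of ethyl on an aromatic carbon, para to a large group, leaves the two compounds within the scatter of each other (a 1.8-fold higher number from compound 3 to compound 4 (0.26 log units; within the scatter)), so this pair does not separate the two groups at this position. Methylsulfanyl in place of methoxy gives a step beyond the scatter (a 6.5-fold higher number from compound 1 to compound 4 (0.81 log units; beyond the scatter)), a second replacement of methoxy to do so after ethyl (a 3.6-fold higher number from compound 1 to compound 3 (0.55 log units; beyond the scatter)), and among the three groups at this position only the methoxy of compound 1 stands apart. Nothing at hand accounts for this difference.

On these data alone, whether an ethoxy, a hydroxyl or a chlorine at this position would stay with methoxy or with the other two groups remains open. Also open, as far as these compounds go, is whether hydrogen in place of the methyl on nitrogen would shift compound 3 or compound 4 as it shifts compound 1.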